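The source may report more compounds than this note shows. Statements on the series, on what has been measured and on what is new or still open speak of the compounds shown alone.

Measured so far in a functional assay on HeLa cells (Homo sapiens) for inhibition, read by MTT assay, with a stated time of 48 h; on this read-out lower numbers stand for stronger inhibition and higher numbers for weaker inhibition:
- compound 1 `Cc1ccc(-c2nc3ccccn3c2Sc2ccccc2)cc1` gives 86700 nM
- compound 2 `c1ccc(Sc2c(-c3cccc4ccccc34)nc3ccccn23)cc1` gives 33100 nM
- compound 3 `c1ccc(Sc2c(-c3ccccc3)nc3ccc(-c4ccccc4)cn23)cc1` gives 72600 nM

Compound 1 and compound 3 sit level within the scatter, while compound 2 has a lower number than compound 1, beyond the scatter. Next is compound 4 `CSc1ccc(-c2nc3ccccn3c2Sc2ccccc2)cc1`, with methylsulfanyl in place of methyl on an aromatic carbon, para to a large group: methylsulfanyl in place of methyl on an aromatic carbon. Within the data shown here, no measured step covers this change, so the starting point is compound 1 at 86700 nM. No step beyond the scatter is expected in this assay. The expected change is a 1.2-fold lower number from compound 1 to compound 4 (0.09 log units; within the scatter). The estimate for compound 4 is 70000 nM, with an expected range of 30000 nM to 150000 nM.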

Compound 4, half-maximal inhibitory concentration: 30000 nM
The estimate for compound 4 lay 2.3-fold (0.37 log units) above the measured number; low and high end bracket the measured number.
By their numbers in this assay, from the lowest: compounds 4 and 2 (each within the scatter of the next); then compounds 3 and 1 (each within the scatter of the next).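

In this assay the change from 4-methylphenyl to 4-(methylsulfanyl)phenyl gives a 2.9-fold lower number from compound 1 to compound 4 (0.46 log units; beyond the scatter) and is the first single-place step in this set, so this position on the aromatic ring is shown to respond to substitution. The step is modest and rests on one pair of compounds. Nothing available gives a reason for it. Open, on these data alone, is whether methoxy, an amine or a longer chain such as ethylsulfanyl at the same position would give a lower number. Also open, as far as these compounds go, is whether the step holds on other cores.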